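This account rests on a few compounds, and the source may have more. Where it says the series, first, only, none or still open, it means among the compounds named here.

In a functional assay on MKN-45 cells (Homo sapiens) for antiproliferative activity, with a stated time of 72 h (on this read-out higher numbers stand for weaker inhibition and lower numbers for stronger inhibition), compound 2 `Cn1cc(-c2ccc(NC(=O)c3cn(CC4CCOCC4)cc(-c4ccc(Cl)cc4)c3=O)cc2)c2c(N)ncnc21` gives 347 nM, and compound 1 `Cn1cc(-c2ccc(NC(=O)c3cn(CC4CCOCC4)cc(-c4ccc(F)cc4F)c3=O)cc2)c2c(N)ncnc21` gives 501 nM. Compound 3 `CN(C)C(=O)Cn1cc(C(=O)Nc2ccc(-c3cn(C)c4ncnc(N)c34)cc2)c(=O)c(-c2ccc(F)cc2)c1` is reported only as a limit, > 100 nM. Compound 4 `Cn1cc(-c2ccc(NC(=O)c3cn(CC4CCOCC4)cc(-c4ccc(C(F)(F)F)cc4)c3=O)cc2)c2c(N)ncnc21` differs from compound 2 by trifluoromethyl in place of chloro on an aromatic carbon, para to a large group: trifluoromethyl in place of chloro on an aromatic carbon. Going by the values given here, the one measured step that bears on this change is the exchange of 2,4-difluorophenyl for 4-chlorophenyl, a 1.4-fold lower number from compound 1 to compound 2 (0.16 log units; within the scatter). It stays within the scatter, so no change beyond the scatter is expected in this assay. The expected size of the change is a 1.0-fold higher number from compound 2 to compound 4 (0.00 log units; within the scatter). For compound 4 the estimated value is 350 nM, with an expected range from 140 nM to 850 nM.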

Compound 4, half-maximal inhibitory concentration: 826 nM
Compound 4: middle estimate off by 2.4-fold (0.37 log units), on the low side; the measured number falls inside the stated range.
By their numbers in this assay, from the lowest: compounds 2, 1 and 4 (each within the scatter of the next, the first and the last beyond it).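

On this aromatic carbon, para to a large group, the step of a 2.4-fold higher number from compound 2 to compound 4 (0.38 log units; beyond the scatter) in this assay is the only one shown that goes beyond the scatter. The other step to the new compound, a 1.6-fold higher number from compound 1 to compound 4 (0.22 log units; within the scatter), stays within it, as the earlier ring exchange did. So this position is not indifferent to its substituent, though the measured difference remains modest, and no measurement shown accounts for it. On these data alone, whether a methoxy group, a nitrile or an amine on this carbon would track chloro or trifluoromethyl remains open.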